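Aryl swap at the saturated ring carbon: thiophene variant

A few compounds are considered here, and "the series" means these few. Any claim that something is new, unique, unknown or untested is made for them only; others in the source may bear on it.

Among the compounds with values here, compound 2 `COc1cc(N2C(N)=C(C#N)C(c3ccccc3O)C3=C2CC(C)(C)CC3=O)cc(OC)c1OC` is the weakest of the three measured members in a functional assay on Ehrlich cells (Mus musculus) for cytotoxicity, tested at 25 ug/mL (a lower number here means a weaker effect, a higher number a stronger effect of the compound at the concentration tested), where compound 2 gives 0%; compound 3 `COc1cc(N2C(N)=C(C#N)C(c3c(O)ccc4ccccc34)C3=C2CC(C)(C)CC3=O)cc(OC)c1OC` gives 10%, and compound 1 `COc1cc(N2C(N)=C(C#N)C(c3ccc([N+](=O)[O-])cc3)C3=C2CC(C)(C)CC3=O)cc(OC)c1OC` gives 50%. Compound 4 `COc1cc(N2C(N)=C(C#N)C(c3cccs3)C3=C2CC(C)(C)CC3=O)cc(OC)c1OC` differs from compound 2 by thiophen-2-yl in place of 2-hydroxyphenyl on a saturated ring carbon. Within the data shown here, two measured steps bear on the same position: a number 50 percentage points lower from compound 1 to compound 2 (beyond the scatter) and a number 40 percentage points lower from compound 1 to compound 3 (beyond the scatter), both large, showing that the group on this carbon can move the read-out strongly; the direct comparison a number 10 percentage points higher from compound 2 to compound 3 (within the scatter) lies within the scatter. Thiophen-2-yl carries neither the nitro group of compound 1 nor the hydroxy group shared by compounds 2 and 3, so no measured pair tells its direction. The starting point of compound 2 already sits at the floor of the read-out, so any step can only go up. A modest rise is expected, a number 15 percentage points higher from compound 2 to compound 4 (beyond the scatter), not clearly beyond the scatter. Compound 4 is estimated at 15% in this assay, in the range 0% to 40%.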

Compound 4, a percentage reported as activity, at one concentration (the size of the read-out at that concentration, not a potency): 10%
The estimate for compound 4 lay 5 percentage points above the measured number; the measured number falls inside the stated range.
By their numbers in this assay, from the lowest: compounds 2, 3 and 4 (each within the scatter of the next); then compound 1.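

In this assay thiophen-2-yl, the only group shown with neither a hydroxy group nor a nitro group, stays level with both hydroxy-bearing aryl groups (a number 10 percentage points higher from compound 2 to compound 4 (within the scatter)) and (no change at the digits printed from compound 3 to compound 4 (within the scatter)). It also falls well short of the 4-nitrophenyl member (a number 40 percentage points lower from compound 1 to compound 4 (beyond the scatter)), so a hydroxy group is not required for a low read-out at this position, and among the four compounds only compound 1 stands apart. No measured evidence bears on the reason for this.

As far as these compounds go, it remains open whether the high read-out of compound 1 belongs to the nitro group itself or to the phenyl ring that carries it; a plain phenyl, or a phenyl bearing an amine or a carboxylic acid instead, would separate these. Read-outs at a single concentration also leave relative potency across the series unresolved.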